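A few compounds are considered here, and "the series" means these few. Any claim that something is new, unique, unknown or untested is made for them only; others in the source may bear on it.

Compound 3, `Cc1cc(-c2ccc(C(F)(F)F)cc2)nnc1N1CCN(c2ncccn2)CC1`, is the weaker of the two compounds that return a number in a functional assay on BV-2 cells (Mus musculus) for inhibition, read by ELISA, with a stated time of 16 h; a lower number here means a stronger inhibitor, a higher number a weaker inhibitor: it gives 37400 nM. Compound 2, `COc1cccc(-c2cc(C)c(N3CCN(c4ncccn4)CC3)nn2)c1`, gives 2600 nM in this assay, a lower number than compound 3 by a margin beyond the scatter. Compound 1, `Cc1cc(Cl)nnc1N1CCN(c2ncccn2)CC1`, returns only a limit in this assay, > 100000 nM, and so the limit of > 100000 nM in this assay, at which 1 of the 3 values shown sits, marks no number at all. Within the data shown here, the one measured step, an at least 38-fold lower number from compound 1 to compound 2 (1.58 log units; beyond the scatter), replaced a chloro with a 3-methoxyphenyl and is not the same change as the one now in question. Compound 4, `COc1ccc(-c2cc(C)c(N3CCN(c4ncccn4)CC3)nn2)cc1`, differs from compound 3 as follows: methoxy in place of trifluoromethyl on an aromatic carbon. Among the measured compounds shown here, no measured step swaps these two groups directly; the values of compound 2 and compound 3 are the only hint, and they place the methoxy-bearing arm well below the trifluoromethyl-bearing one. Compound 4 is therefore expected to give a lower number than compound 3, a step of about a 6.2-fold lower number from compound 3 to compound 4 (0.79 log units; beyond the scatter). The estimate for compound 4 in this assay is 6000 nM, within a range from 1500 nM to 25000 nM.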

Compound 4, half-maximal inhibitory concentration: 5200 nM
Compound 4: the middle estimate sits 1.2-fold (0.06 log units) above what was measured; the range from low to high includes it.
By their numbers in this assay, from the lowest: compounds 2 and 4 (each within the scatter of the next); then compound 3. At a limit, above all of these: compound 1.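

With the two groups now compared directly on the same aromatic carbon, methoxy in place of trifluoromethyl gives a 7.2-fold lower number from compound 3 to compound 4 (0.86 log units; beyond the scatter) in this assay, so the group on this ring alone moves the number by a margin beyond the scatter. Moving the methoxy, with 4-methoxyphenyl in place of 3-methoxyphenyl, gives a 2.0-fold higher number from compound 2 to compound 4 (0.30 log units; within the scatter), so these two arrangements cannot be told apart here. A second aryl group in place of chloro also gives a large step, an at least 19-fold lower number from compound 1 to compound 4 (1.28 log units; beyond the scatter), though it is read against a limit and not a number: the limit of > 100000 nM in this assay, at which 1 of the 4 values shown sits.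

The compounds shown leave open how an amine, a nitrile or a carboxylic acid at this place would compare with methoxy and trifluoromethyl. They also leave open whether a phenyl ring with no such group would already give a number.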